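Two Bromo Groups on the Shared Core

This account rests on a few compounds, and the source may have more. Where it says the series, first, only, none or still open, it means among the compounds named here.

The series rests on a shared core carrying a substituted bicyclic amine, and the readings come from a functional assay on MCF7 cells (Homo sapiens) for inhibition, read by MTT assay, with a stated time of 48 h; a higher number here means a weaker inhibitor, a lower number a stronger inhibitor. Compound 1 `O=c1cc(-c2ccccc2)oc2cc(N3COc4c(Cl)cc(Cl)cc4C3)ccc12`, the analogue bearing chloro groups, gives 44500 nM in this assay, a weak result. Compound 2 `O=c1cc(-c2ccccc2)oc2cc(N3COc4c(Br)cccc4C3)ccc12`, which bears a single bromo group, has no single number in this assay: it is recorded as "not active" (no number reported), so its standing cannot be placed on the scale that compound 1 occupies, beyond being at the weak end.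

Compound 3 `O=c1cc(-c2ccccc2)oc2cc(N3COc4c(Br)cc(Br)cc4C3)ccc12` is the next member, not yet measured. It differs from compound 2 by bromo in place of hydrogen on an aromatic carbon, so that the ring of the amine now carries a pattern of halogens matching that of compound 1. For the measured compounds named here, no measured pair in this set shows such a step, so its size cannot be read from data. Given that compound 2 is reported inactive and compound 1 is itself weak, compound 3 is expected to remain weak in this assay, and a reading of 50000 nM, between 15000 nM and 150000 nM, is estimated, with a real chance that only inactivity is reported.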

Compound 3, half-maximal inhibitory concentration: "not active" (no number reported)
For compound 3 the study gives words and no number, so the estimate cannot be set against anything.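

In this assay compound 2 and compound 3 are both reported in words alone, so no step can be read between them. The compounds shown leave open whether the added bromo group changes inhibition at all, since neither compound has a number. Nothing shown offers an explanation for this result.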